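Acetamido-chlorophenyl urea analogue of compound 3

The source may report more compounds than this note shows. Statements on the series, on what has been measured and on what is new or still open speak of the compounds shown alone.

Compound 3 `COc1cccc(NC(=O)Nc2cccc(-c3nc(-c4ccc(NC(=O)c5cccnc5)cc4Cl)no3)c2)c1` is examined in a functional assay on MDA-MB-231 cells (Homo sapiens) for antiproliferative activity, read by MTT assay, with a stated time of 72 h (on this read-out higher numbers stand for weaker inhibition and lower numbers for stronger inhibition), where compound 3 gives 6700 nM, the highest of the two numbers obtained; its closest neighbour is compound 2 `NC(=O)Nc1ccc(S(=O)(=O)Nc2cccc(-c3nc(-c4ccc(NC(=O)c5cccnc5)cc4Cl)no3)c2)cc1`, for which compound 2 gives 2800 nM. Compound 1 `CC(=O)Nc1ccc(S(=O)(=O)Nc2cccc(-c3nc(-c4ccc(NC(=O)c5cccnc5)cc4Cl)no3)c2)cc1C` reaches only a limit in this assay, and compound 1 gives > 10000 nM. Compound 4 `CC(=O)Nc1ccc(NC(=O)Nc2cccc(-c3nc(-c4ccc(NC(=O)c5cccnc5)cc4Cl)no3)c2)cc1Cl` differs from compound 3 by 4-acetamido-3-chlorophenyl in place of 3-methoxyphenyl on an amide-type nitrogen.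

Within the data shown here, only one measured step is available, and it sits on a sulfonyl sulfur rather than on the amide-type nitrogen: an at least 3.5-fold lower number from compound 1 to compound 2 (0.55 log units; beyond the scatter). There the group carrying an acetamido and a small ring substituent was the one held at the limit (the limit of > 10000 nM in this assay, at which 1 of the 3 values shown sits), whereas here a closely related acetamido-bearing group enters. He therefore expects the number for compound 4 to move upward, if anywhere, and a limit cannot be excluded. His estimate for compound 4 is 10000 nM, ranging from 4000 nM to 25000 nM, an expected step of a 1.5-fold higher number from compound 3 to compound 4 (0.17 log units; within the scatter).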

Compound 4, half-maximal inhibitory concentration: > 10000 nM
Compound 4 was reported as a limit; the forecaster's own chance of this, stated with the estimate: 45%; the middle value lies on the limit itself.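

In this assay compound 4 gives > 10000 nM, which is a limit of the assay and not a number. As far as these compounds go, the step therefore fixes only a floor, an at least 1.4-fold higher number from compound 3 to compound 4 (0.17 log units; that floor lies within the scatter), so exchanging the 3-methoxyphenyl on this amide-type nitrogen for 4-acetamido-3-chlorophenyl gives no confirmed loss, and the true size of the change stays unknown. What is new is that an acetamido-bearing group now stands at the limit on this amide-type nitrogen as well as on the sulfonyl sulfur, with compound 1 and compound 4 there and compound 2 and compound 3 giving measured numbers: the limit of > 10000 nM in this assay, at which 2 of the 4 values shown sit.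

The compounds shown do not separate the acetamido from the chlorine within 4-acetamido-3-chlorophenyl. They also leave open how a free 4-aminophenyl or a 4-carboxyphenyl would read on this nitrogen.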